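The compounds below may be only part of what the source reports. "The series", "measured", "known", "first", "only" and "open" are said of these compounds alone.

Compound 1 `Nc1nc2[nH]c(CCCCCC(=O)N[C@@H](CCC(=O)O)C(=O)O)cc2c(=O)[nH]1`: > 1000 nM
Compound 2 `Nc1nc2[nH]c(CCCCCCCCC(=O)N[C@@H](CCC(=O)O)C(=O)O)cc2c(=O)[nH]1`: > 10000 nM
Compound 3 `Nc1nc2[nH]c(CCCCCC(=O)O)cc2c(=O)[nH]1`: > 1000 nM

All three results in a functional assay on RT16 cells (Cricetulus griseus) for inhibition, read by CellTiter-Blue, with a stated time of 96 h, in the presence of a further agent that is not named here (on this read-out higher numbers stand for weaker inhibition and lower numbers for stronger inhibition), are limits of the assay, not numbers. Compound 3 sits at the limit of > 1000 nM in this assay, at which 2 of the 3 values shown sit, and compound 2 sits at the limit of > 10000 nM in this assay, at which 1 of the 3 values shown sits. Compound 4 `Nc1nc2[nH]c(CCCCCCC(=O)O)cc2c(=O)[nH]1` differs from compound 3 by one change: carboxymethyl in place of carboxy on a saturated chain carbon, five bonds along the chain from an aromatic carbon, carboxymethyl in place of carboxy on a saturated chain carbon. Within the data shown here, no measured pair gives a size for this change, so no shift beyond the usual scatter is expected in this assay, in either direction. This expectation rests on compound 3, whose limit is > 1000 nM. The expected change is a step that the limit leaves unreadable from compound 3 to compound 4. Compound 4 is estimated at 2000 nM, with an expected range of 1000 nM to 10000 nM.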

Compound 4, half-maximal inhibitory concentration: > 1000 nM
Compound 4: a limit, no number; the forecaster's own chance of this, stated with the estimate: 90%; the middle value does not contradict the limit.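

Among these compounds, compound 3 and compound 4 both stand only as limits of the assay, so no step between them can be read. The compounds shown leave open whether carboxymethyl in place of carboxy changes inhibition at all, and in which direction.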